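Removing One Trifluoromethyl Group from Compound 2

The source may report more compounds than this note shows. Statements on the series, on what has been measured and on what is new or still open speak of the compounds shown alone.

Measured compounds:
Compound 1, `Cc1nc(N(C)C(=O)NC(=O)c2c(F)cccc2F)sc1C(=O)N/N=C/c1ccc(C(F)(F)F)cc1`, gives a limit of > 100 ug/mL in a functional assay on HepG2 cells (Homo sapiens) for inhibition, read by MTT assay, with a stated time of 72 h; a lower number here means a stronger inhibitor, a higher number a weaker inhibitor.
Compound 2, `CN(C(=O)NC(=O)c1c(F)cccc1F)c1nc(C(F)(F)F)c(C(=O)N/N=C/c2cc(C(F)(F)F)cc(C(F)(F)F)c2)s1`, gives 6.28 ug/mL in this assay.
Compound 3, `CN(C(=O)NC(=O)c1ccc(F)c(F)c1)c1nc(C(F)(F)F)c(C(=O)N/N=C/c2cc(C(F)(F)F)cc(C(F)(F)F)c2)s1`, gives 5.47 ug/mL in this assay.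

Among the numbers shown, compound 2 stands highest of the two, with compound 3 nearest: a 1.1-fold lower number from compound 2 to compound 3 (0.06 log units; within the scatter). Compound 1 sits at the limit of > 100 ug/mL in this assay, at which 1 of the 3 values shown sits; a limit says only that the assay reported no number for it. The unmeasured compound 4, `CN(C(=O)NC(=O)c1c(F)cccc1F)c1nc(C(F)(F)F)c(C(=O)N/N=C/c2cccc(C(F)(F)F)c2)s1`, differs from compound 2 in one place: hydrogen in place of trifluoromethyl on an aromatic carbon. Among the measured compounds shown here, the only measured step, from compound 2 to compound 3, alters the difluorophenyl at the other end of the molecule and stays within the scatter; no measured step touches the ring that carries the trifluoromethyl groups, so nothing here shows how much one of them matters. For the measured compounds named here, compound 1 differs from compound 2 in more than one place and shows only a limit, so it supplies no single step. The expectation is therefore a small change with wide uncertainty: the step from compound 2 to compound 4 is expected to be a 1.3-fold higher number from compound 2 to compound 4 (0.11 log units; within the scatter). Compound 4 is estimated at 8 ug/mL, between 3 ug/mL and 25 ug/mL.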

Compound 4, half-maximal inhibitory concentration: 27.9 ug/mL
Beside the measured number, compound 4's estimate is 3.5-fold (0.54 log units) below it; measured number outside the range, above it.
By their numbers in this assay, from the lowest: compounds 3 and 2 (each within the scatter of the next); then compound 4. At a limit, above all of these: compound 1.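

Taking one trifluoromethyl group off the aromatic ring and leaving hydrogen in its place gives, in this assay, a 4.4-fold higher number from compound 2 to compound 4 (0.65 log units; beyond the scatter), so this position on the ring does affect the result and compound 4 is the weaker inhibitor of the pair. Among the compounds shown here, the only earlier step, a 1.1-fold lower number from compound 2 to compound 3 (0.06 log units; within the scatter), changed the difluorophenyl at the other end of the molecule and stayed within the scatter, so it gave no hint that a single substituent could move the number beyond the scatter. The data shown measure the size of this change but offer nothing that explains it.

From the compounds shown here alone, it remains open whether trifluoromethyl itself matters at this place or whether a chlorine atom, a methoxy group or an amine in the same position would restore the number of compound 2, and what would follow if the remaining trifluoromethyl group on this ring were replaced as well. It is also unknown whether the same change would have a step of similar size in compound 3, which carries 3,4-difluorophenyl in place of 2,6-difluorophenyl.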